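This account rests on a few compounds, and the source may have more. Where it says the series, first, only, none or still open, it means among the compounds named here.

Compound 1 `Nc1nc(N)c2cc(CSC(=S)N3CCN(C4CCCCC4)CC3)ccc2n1`: 8400 nM
Compound 2 `Cc1ccc(N2CCN(C(=S)SCc3ccc4nc(N)nc(N)c4c3)CC2)cc1`: 5510 nM
Compound 3 `Cc1ccccc1N1CCN(C(=S)SCc2ccc3nc(N)nc(N)c3c2)CC1`: 11800 nM

All three values come from a functional assay on HCT-116 cells (Homo sapiens) for antiproliferative activity, read by MTT assay, with a stated time of 72 h; a lower number here means a stronger inhibitor, a higher number a weaker inhibitor. Compound 3, at 11800 nM, has no clear separation from compound 1, as the data show a 1.4-fold higher number from compound 1 to compound 3 (0.15 log units; within the scatter). Its separation from compound 2 is modest but real, with a 2.1-fold higher number from compound 2 to compound 3 (0.33 log units; beyond the scatter).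

The next compound is compound 4 `Nc1nc(N)c2cc(CSC(=S)N3CCN(c4ccccc4Cl)CC3)ccc2n1`, which has chloro in place of methyl on an aromatic carbon, ortho to a large group (chloro in place of methyl on an aromatic carbon). The same difference reads as 2-methylphenyl to 2-chlorophenyl. Going by the values given here, no measured pair makes this exact exchange, so the evidence is indirect. The closest guide is the shift of the methyl group on that ring, which gave a 2.1-fold higher number from compound 2 to compound 3 (0.33 log units; beyond the scatter). Replacing the whole ring substituent gave only a 1.5-fold lower number from compound 1 to compound 2 (0.18 log units; within the scatter). Across these three compounds, then, changes on this ring nitrogen moved the number little in this assay. A swap of one single atom for another at an unchanged position therefore gives no reason to expect a step beyond the scatter, in either direction. The expected step is a 1.2-fold lower number from compound 3 to compound 4 (0.09 log units; within the scatter). For compound 4 the estimated value is 9500 nM. The expected range for compound 4 runs from 4500 nM to 20000 nM.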

Compound 4, half-maximal inhibitory concentration: 5490 nM
The estimate for compound 4 lay 1.7-fold (0.24 log units) above the measured number, and the stated range covers the measured number.
By their numbers in this assay, from the lowest: compounds 4, 2, 1 and 3 (each within the scatter of the next, the first and the last beyond it).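

In this assay, exchanging methyl for chloro on this aromatic carbon, ortho to a large group, gave a modest step beyond the scatter (a 2.1-fold lower number from compound 3 to compound 4 (0.33 log units; beyond the scatter)), so a change of one atom here moved the number as far as moving the methyl group did (a 2.1-fold higher number from compound 2 to compound 3 (0.33 log units; beyond the scatter)). Going by these compounds alone, compound 4 shows no separation from the other two compounds (a 1.0-fold lower number from compound 2 to compound 4 (0.00 log units; within the scatter); a 1.5-fold lower number from compound 1 to compound 4 (0.18 log units; within the scatter)), which places 2-chlorophenyl with 4-methylphenyl and cyclohexyl and leaves 2-methylphenyl as the only group that stands apart from any other, and even then not from cyclohexyl in compound 1. Nothing given here explains why chloro and methyl differ at this carbon.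

As far as these compounds go, it remains open whether the step is specific to chloro or would also appear with other groups at this carbon, such as fluoro, methoxy or a nitrile. The compounds shown also do not tell whether 4-chlorophenyl would match 2-chlorophenyl, or whether an unsubstituted phenyl would sit with the 2-methylphenyl compound or with the rest.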